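The compounds below may be only part of what the source reports. "The series", "measured", "known", "first", "only" and "open" are said of these compounds alone.

Of the compounds shown here, two have numbers so far. Compound 1 `O=c1cc(/C=N\c2ccc(O)cc2)c2ccc(OCc3ccccc3)cc2o1` and compound 2 `Nc1ccccc1/N=C\c1cc(=O)oc2cc(OCc3ccccc3)cc(OCc3ccccc3)c12` are built on a shared core, and both carry a benzyloxy group. In a functional assay, read by spectrophotometry, with a stated time of 5 min (a lower number here means a stronger inhibitor, a higher number a weaker inhibitor), compound 1 gives 525000 nM, while compound 2 gives 258000 nM. Compound 2 therefore stands at the lower of the two numbers, and its gap to compound 1 is beyond the usual scatter of repeated measurements. Compound 3 `Nc1ccccc1/N=C\c1cc(=O)oc2cc(OCc3ccccc3)ccc12` has not yet been measured in this assay. It differs from compound 2 in one place: hydrogen in place of benzyloxy on an aromatic carbon. For the measured compounds named here, no pair of measured compounds differs in just this way, so there is no direct precedent for the step. Going by the values given here, compound 1 also carries a single benzyloxy group and sits at the higher number, but it differs from compound 2 elsewhere as well, so it shows only that a core with one such group can still reach this level. The expected step is a 1.5-fold higher number from compound 2 to compound 3 (0.17 log units; within the scatter), small and, if anything, toward a higher number. On this basis compound 3 is expected to give 380000 nM in this assay, with a likely range from 130000 nM to 1100000 nM.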

Compound 3, half-maximal inhibitory concentration: 217000 nM
Beside the measured number, compound 3's estimate is 1.8-fold (0.24 log units) above it, within the range that was stated.
By their numbers in this assay, from the lowest: compounds 3 and 2 (each within the scatter of the next); then compound 1.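

In this assay, replacing benzyloxy with hydrogen on this aromatic carbon gives a 1.2-fold lower number from compound 2 to compound 3 (0.08 log units; within the scatter) and so removes a whole six-membered aromatic ring and 8 heavy atoms with no difference that this assay can separate from scatter. The other step, with 2-aminophenyl in place of 4-hydroxyphenyl on a double-bonded nitrogen, is a 2.4-fold lower number from compound 1 to compound 3 (0.38 log units; beyond the scatter) and shows that, with a single benzyloxy group on the shared core, the group on that nitrogen does register, although only modestly. Nothing available explains either step, so the reason for these results remains unknown.

The compounds shown leave open whether a different group on this aromatic carbon, such as methoxy or an amine, would also read the same as hydrogen and benzyloxy. They also leave open whether the step at the nitrogen depends on the amino group itself or on where it sits, a question that a plain phenyl or a 4-aminophenyl on that nitrogen could help to settle.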